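The compounds below may be only part of what the source reports. "The series", "measured", "known", "first", "only" and "open" are said of these compounds alone.

Measured compounds:
- compound 1, `Nc1scc(CN2CCN(c3ccccc3C(F)(F)F)CC2)c1C(=O)c1ccc(Cl)cc1`: -60%
- compound 2, `Nc1scc(CN2CCN(c3ccc(Cl)c(C(F)(F)F)c3)CC2)c1C(=O)c1ccc(Cl)cc1`: -60%

Both values come from a functional assay on CHO cells with adenosine receptor A1 (Homo sapiens) as the target, read by cAMP accumulation and immunoassay, with a stated time of 6 min, tested at 10 uM; a lower number here means a stronger effect, a higher number a weaker effect of the compound at the concentration tested. In this assay, within the data shown here, compound 2 gives -60% and stands level with compound 1 at the digits printed; the only measured step, no change at the digits printed from compound 1 to compound 2 (within the scatter), lies within the scatter, so the exchange of 2-(trifluoromethyl)phenyl for 4-chloro-3-(trifluoromethyl)phenyl on an amine nitrogen in a ring left the read-out where it was.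

Compound 3, `Nc1scc(CN2CCN(c3ccncc3)CC2)c1C(=O)c1ccc(Cl)cc1`, is not yet measured in this assay. It differs from compound 2 as follows: pyridin-4-yl in place of 4-chloro-3-(trifluoromethyl)phenyl on an amine nitrogen in a ring. Among the measured compounds shown here, no measured step covers this kind of change: the one step available kept a six-membered aromatic ring of carbon only on the amine nitrogen and only moved its substituents, whereas here that ring gives way to pyridin-4-yl. The measured step therefore bears only weakly on the expectation. The expected step of a number 15 percentage points higher from compound 2 to compound 3 (beyond the scatter) is set near no change, with a wide range to allow for a weaker effect. For compound 3 the estimate in this assay is -45%, range -80% to 0%.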

Compound 3, a percentage reported as activity, at one concentration (the size of the read-out at that concentration, not a potency): -15%
The estimate for compound 3 lay 30 percentage points below the measured number, and the stated range covers the measured number.
By their numbers in this assay, from the lowest: compounds 1 and 2 (each within the scatter of the next); then compound 3.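

In this assay the place on the amine nitrogen of the six-membered ring proves sensitive to which aromatic ring it carries: pyridin-4-yl in place of 4-chloro-3-(trifluoromethyl)phenyl gives a number 45 percentage points higher from compound 2 to compound 3 (beyond the scatter) and pyridin-4-yl in place of 2-(trifluoromethyl)phenyl gives a number 45 percentage points higher from compound 1 to compound 3 (beyond the scatter) as the effect at the concentration tested weakens. Among these compounds, the earlier pair, with two differently substituted rings of carbon only, could not be told apart, so this exchange for a ring with one hetero atom, which also removes the chlorine and fluorine atoms of compound 2, is the first change to move the read-out beyond the scatter. No measured information is available to explain the loss.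

The compounds shown do not separate the ring nitrogen from the lost substituents, a question that unsubstituted phenyl on the same nitrogen would address. Also open, going by these compounds, is whether the ring nitrogen's place matters, as pyridin-3-yl or pyridin-2-yl would show, and whether a chlorine or methoxy group on the pyridine ring would restore the effect.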